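Replacing Acetyl on an Aromatic Nitrogen

The source may report more compounds than this note shows. Statements on the series, on what has been measured and on what is new or still open speak of the compounds shown alone.

In a functional assay on HT-29 cells (Homo sapiens) for cytotoxicity (on this read-out lower numbers stand for stronger inhibition and higher numbers for weaker inhibition), compound 2 `CC(=O)n1nc(N)c2c(-c3ccccc3)c(-c3ccccc3)nnc21` gives > 100000 nM, which is a limit of the assay. Compound 1 `Nc1nn(Cc2ccccc2)c2nnc(-c3ccccc3)c(-c3ccccc3)c12` gives > 100000 nM, also a limit. Compound 3 `CC(=O)Nc1nn(C(C)=O)c2nnc(-c3ccccc3)c(-c3ccccc3)c12` gives > 100000 nM, again a limit. The evidence so far is therefore (the limit of > 100000 nM in this assay, at which 3 of the 3 values shown sit). Compound 4 `Nc1nn(CCOCCO)c2nnc(-c3ccccc3)c(-c3ccccc3)c12` carries 2-(2-hydroxyethoxy)ethyl in place of acetyl on an aromatic nitrogen. The closest measured change, acetyl in place of benzyl on an aromatic nitrogen, is a step that the two limits leave unreadable from compound 1 to compound 2. Acetyl in place of hydrogen on a nitrogen on an aromatic ring is a step that the two limits leave unreadable from compound 2 to compound 3. Neither gives a size or a direction, so no change beyond the scatter is expected, and the expected step is a number no higher from compound 2 to compound 4 (the limit leaves the size open). For compound 4 the estimated value is 100000 nM, with an expected range of 30000 nM to 200000 nM.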

Compound 4, half-maximal inhibitory concentration: > 100000 nM
Compound 4: no number, only a limit; the forecaster's own chance of this, stated with the estimate: 75%; the middle value lies on the limit itself.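

In this assay compound 4 gives > 100000 nM, again a limit, so its steps from compound 1 and compound 2 cannot be read. The compounds shown leave open whether any group on the aromatic nitrogen changes the read-out.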